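Anilide swap on the shared core: from ethyl to methyl

The compounds below may be only part of what the source reports. "The series", "measured", "known", "first", "only" and "open" are said of these compounds alone.

Measured compounds:
compound 1, `CCc1ccc(NC(=O)C2Cc3cc(OC)c(OC)cc3C2=O)cc1`, 76.2 ug/mL
compound 2, `COc1cc2c(cc1OC)C(=O)C(C(=O)Nc1ccc(F)cc1)C2`, 55 ug/mL

In a physicochemical assay, with a stated time of 30 min (a lower number here means a stronger inhibitor, a higher number a weaker inhibitor), compound 1 gives the higher of the two numbers; its nearest neighbour is compound 2, and the step of a 1.4-fold lower number from compound 1 to compound 2 (0.14 log units; within the scatter) stays within the scatter. Compound 3, `COc1cc2c(cc1OC)C(=O)C(C(=O)Nc1ccccc1C)C2`, is not yet measured. It differs from compound 1 by 2-methylphenyl in place of 4-ethylphenyl on an amide-type nitrogen. Going by the values given here, no measured step exchanges one substituted phenyl on the amide-type nitrogen for another of this kind; the only step on record, from compound 1 to compound 2, is within the scatter. The step of a 1.1-fold lower number from compound 1 to compound 3 (0.04 log units; within the scatter) is therefore expected to be none beyond the scatter. For compound 3 the estimate in this assay is 70 ug/mL, within 35 ug/mL to 140 ug/mL.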

Compound 3, half-maximal inhibitory concentration: 43.7 ug/mL
Estimate against measurement, compound 3: 1.6-fold (0.20 log units) above, within the range that was stated.
By their numbers in this assay, from the lowest: compounds 3, 2 and 1 (each within the scatter of the next).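

In this assay the exchange of one substituted phenyl for another on the amide-type nitrogen gives a 1.7-fold lower number from compound 1 to compound 3 (0.24 log units; within the scatter) and, with 4-fluorophenyl as the group replaced, a 1.3-fold lower number from compound 2 to compound 3 (0.10 log units; within the scatter). Both steps stay within the scatter, so compounds 1, 2 and 3 cannot be told apart, whether the phenyl carries ethyl, fluoro or methyl. No measurement here offers an explanation for how close these numbers lie. Still open, on these data alone, is whether an amine or a carboxylic acid on this phenyl, or a longer chain in its place, would give a step beyond the scatter.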